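The source may hold more compounds than are shown below. What is called first, only, known or untested is meant among the compounds shown, and "the series" means these compounds.

Working notes on the series. Compound 1 `Cc1ccccc1-c1cnnc(NCc2cc(-c3ccccc3)[nH]n2)n1` and compound 2 `Cc1ccccc1-c1ccnc(NCc2cc(-c3ccccc3)[nH]n2)c1` carry the same side group on two different cores; the difference between the two cores is not broken down here. In an ADME assay on CEM174 cells (Homo sapiens) for cytotoxicity (on this read-out lower numbers stand for higher toxicity in this test and higher numbers for lower toxicity in this test), compound 1 gives > 10000 nM, which is a limit of the assay and not a number. In this assay compound 2 gives > 10000 nM, likewise a limit. Compound 3 `Cc1cc(C#N)ccc1-c1cnnc(NCc2cc(-c3ccccc3)[nH]n2)n1` arises from compound 1 by cyano in place of hydrogen on an aromatic carbon. In this assay compound 3 gives > 10000 nM, again only a limit. The step that the two limits leave unreadable from compound 1 to compound 3 cannot be sized because of the limit of > 10000 nM in this assay, at which 3 of the 3 values shown sit. Compound 4 `Cc1cc(C#N)ccc1-c1ccnc(NCc2cc(-c3ccccc3)[nH]n2)c1` stands to compound 2 as compound 3 stands to compound 1: the change cyano in place of hydrogen on an aromatic carbon is the same change, at a place described in the same words. For compound 4 the expected step is a step that the limit leaves unreadable from compound 2 to compound 4, resting on the step that the two limits leave unreadable from compound 1 to compound 3, which left the same change unreadable on the other core. Compound 4 is therefore expected to sit at roughly 20000 nM, with a range from 10000 nM to 60000 nM, most likely reported as a limit only.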

Compound 4, half-maximal cytotoxic concentration: > 10000 nM
Compound 4 ended at the assay's limit; the forecaster's own chance of this, stated with the estimate: 85%; the middle value is on the limit's open side.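

Compound 2 and compound 4 both stand only at a limit of the assay, so no step can be read for cyano in place of hydrogen on an aromatic carbon in this assay: the limit of > 10000 nM in this assay, at which 4 of the 4 values shown sit. The compounds shown leave open whether this change alters cytotoxicity on either core, and at what concentration any of the four becomes toxic.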